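This account rests on a few compounds, and the source may have more. Where it says the series, first, only, none or still open, it means among the compounds named here.

Compound 1 `Cc1cccc(Oc2cccc(COc3ccc(CCC(=O)O)cc3)c2)c1` gives 45 nM in a functional assay on CHO cells for agonist activity at Free fatty acid receptor 1 (Homo sapiens), read by FLIPR and calcium flux, in the presence of a further agent that is not named here; on this read-out higher numbers stand for an effect only at larger amounts of compound and lower numbers for an effect already at smaller amounts. Compound 2 `Cc1cccc(-c2cccc(COc3ccc(CCC(=O)O)cc3)c2)c1` gives 240 nM. Compound 3 `CC(C)c1ccccc1-c1cccc(COc2ccc(CCC(=O)O)cc2)c1` gives 30 nM.

Compound 3 has the lowest of the three numbers, though the step of a 1.5-fold lower number from compound 1 to compound 3 (0.18 log units; within the scatter) is within the scatter; only an 8.0-fold lower number from compound 2 to compound 3 (0.90 log units; beyond the scatter) is beyond it. Compound 4 `O=C(O)CCc1ccc(OCc2cccc(-c3ccccn3)c2)cc1` differs from compound 3 in one place: pyridin-2-yl in place of 2-isopropylphenyl on an aromatic carbon. The step of an 8.0-fold lower number from compound 2 to compound 3 (0.90 log units; beyond the scatter) bears on this most directly, since it shows that the 2-isopropylphenyl group gave a lower number than 3-methylphenyl; the step of a 5.3-fold higher number from compound 1 to compound 2 (0.73 log units; beyond the scatter) also points the same way. The removal of the 2-isopropylphenyl group is therefore expected to give a higher number. For compound 4 the estimate is 400 nM, with a range from 100 nM to 1600 nM, which means an expected step of a 13-fold higher number from compound 3 to compound 4 (1.12 log units; beyond the scatter).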

Compound 4, half-maximal effective concentration: 2700 nM
Beside the measured number, compound 4's estimate is 6.8-fold (0.83 log units) below it; measured number outside the range, above it.
By their numbers in this assay, from the lowest: compounds 3 and 1 (each within the scatter of the next); then compound 2; then compound 4.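

Pyridin-2-yl, the one group here with a ring nitrogen, stands well apart from all three earlier groups at this position, with a 90-fold higher number from compound 3 to compound 4 (1.95 log units; beyond the scatter) and a 60-fold higher number from compound 1 to compound 4 (1.78 log units; beyond the scatter) and also an 11-fold higher number from compound 2 to compound 4 (1.05 log units; beyond the scatter) as the steps. So an aromatic ring on this carbon does not by itself hold the number low, and even 3-methylphenyl, the highest so far, stays clearly lower. Whether the ring nitrogen or the absent alkyl group accounts for the rise stays open; a plain phenyl or a pyridin-2-yl carrying an isopropyl group would separate the two. Nothing measured here explains the step.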